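This account rests on a few compounds, and the source may have more. Where it says the series, first, only, none or still open, it means among the compounds named here.

Measured so far:
Compound 1 `CSc1nc(=O)ccn1[C@@H]1O[C@H](COP(=O)(O)OP(=O)(O)O)[C@@H](O)[C@H]1O` gives 1520 nM in an in vitro functional assay on 1321-N1 cells for agonist activity at P2Y purinoceptor 4 (Homo sapiens), read by scintillation proximity assay and inositol phosphate accumulation; on this read-out lower numbers stand for an effect already at smaller amounts and higher numbers for an effect only at larger amounts of compound.
Compound 2 `O=c1ccn([C@@H]2O[C@H](COP(=O)(O)O)[C@@H](O)[C@H]2O)c(SCCc2ccccc2)n1` gives only a limit, > 100000 nM, in this assay.

Compound 2 thus stands at the limit of this assay, as noted in the limit of > 100000 nM in this assay, at which 1 of the 2 values shown sits; no number for it is known. Compound 3 `CSc1nc(=O)ccn1[C@@H]1O[C@H](COP(=O)(O)O)[C@@H](O)[C@H]1O` differs from compound 2 by hydrogen in place of benzyl on a saturated chain carbon bound to a sulfur. The shared core of compound 3 also appears in compound 1, which carries a second phosphate. Because compound 2 sits at a limit > 100000 nM, the size of the step cannot be measured from it. The expected step is an at least 3.3-fold lower number from compound 2 to compound 3 (0.52 log units; beyond the scatter), toward smaller amounts, though weakly founded. Compound 3 is estimated at 30000 nM, between 5000 nM and 150000 nM.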

Compound 3, half-maximal effective concentration: > 100000 nM
Compound 3: a limit, no number (the forecaster's own chance of this, stated with the estimate: 40%); at least 3.3-fold (0.52 log units) between middle value and limit.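

With the methylsulfanyl group held the same, the second phosphate can now be judged on its own: its loss gives an at least 65-fold higher number from compound 1 to compound 3 (1.81 log units; beyond the scatter). The change from phenethyl to methyl cannot be read, because compound 2 and compound 3 both sit at a limit: the limit of > 100000 nM in this assay, at which 2 of the 3 values shown sit.

From the compounds shown here alone, what the phenethylsulfanyl group does when the second phosphate is present remains open. So does the effect of an amine or a longer chain in place of methyl, with either one phosphate or two.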